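Cyclopropylmethyl replaces phenyl on the shared imidazole core

A few compounds are considered here, and "the series" means these few. Any claim that something is new, unique, unknown or untested is made for them only; others in the source may bear on it.

Measured so far in an in vitro functional assay on cells for agonist activity at Bombesin receptor subtype-3 (Mus musculus), read by luminescence and calcium flux; a lower number here means that less compound is needed, a higher number that more compound is needed for the effect:
compound 1 `N#Cc1cccc(Cc2cnc(CCc3ccc(-c4ccccc4C(=O)O)cc3)[nH]2)c1` gives 20 nM;
compound 2 `CC(C)CCc1cnc(CCc2ccc(-c3ccccc3C(=O)O)cc2)[nH]1` gives 10 nM;
compound 3 `O=C(O)c1ccccc1-c1ccc(CCc2ncc(-c3ccccc3)[nH]2)cc1` gives 872 nM.

Compound 3 therefore stands with the highest number of the three, and both of its steps from the others lie beyond the scatter. Compound 4 `O=C(O)c1ccccc1-c1ccc(CCc2ncc(CC3CC3)[nH]2)cc1` differs from it in one place: cyclopropylmethyl in place of phenyl on an aromatic carbon. Among the compounds with values here, two measured steps bear on this change, since both swap the group at the same ring carbon for a chain-linked group: a 44-fold higher number from compound 1 to compound 3 (1.64 log units; beyond the scatter) and an 87-fold higher number from compound 2 to compound 3 (1.94 log units; beyond the scatter). Reversing a change of that kind, from the flat phenyl to a chain-linked group, is expected to give a large step downward in this assay for compound 4, a 29-fold lower number from compound 3 to compound 4 (1.46 log units; beyond the scatter). Compound 4 is thus estimated at 30 nM, within a range from 8 nM to 120 nM.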

Compound 4, half-maximal effective concentration: 72 nM
For compound 4 the middle estimate is 2.4-fold (0.38 log units) below the measured one; the measured number falls inside the stated range.
By their numbers in this assay, from the lowest: compounds 2 and 1 (each within the scatter of the next); then compound 4; then compound 3.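

In this assay, cyclopropylmethyl on the aromatic carbon gives a 12-fold lower number from compound 3 to compound 4 (1.08 log units; beyond the scatter) as phenyl leaves, so a small saturated ring on a chain carbon recovers much of the gap that compound 3 showed. The recovery is only partial, with a 7.2-fold higher number from compound 2 to compound 4 (0.86 log units; beyond the scatter) and a 3.6-fold higher number from compound 1 to compound 4 (0.56 log units; beyond the scatter) in the other direction, so the group borne on that chain carbon also counts, and not only the presence of the chain. No measurement shown explains these differences.

The compounds shown leave open how an amine or a hydroxyl group on this chain would fare. They also leave open whether a longer chain than isopentyl would hold the number of compound 2.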